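Notes on the step from compound 3 to compound 4

This account rests on a few compounds, and the source may have more. Where it says the series, first, only, none or still open, it means among the compounds named here.

Measured in a functional assay on U-251 cells (Homo sapiens) for antiproliferative activity, read by MTT assay, with a stated time of 48 h; a higher number here means a weaker inhibitor, a lower number a stronger inhibitor:
- compound 1 `COc1cc(-c2cccc3nc(-c4ccccc4)oc23)cc(OC)c1OC`: 3500 nM
- compound 2 `COc1ccc(-c2nc3cccc(-c4cc(OC)c(OC)c(OC)c4)c3o2)cc1`: > 25000 nM, a limit of the assay
- compound 3 `COc1ccc(-c2nc3cccc(-c4cc(OC)c(OC)c(OC)c4)c3o2)cc1F`: 1700 nM

Compound 3 has the lowest number of the three, and a 2.1-fold lower number from compound 1 to compound 3 (0.31 log units; beyond the scatter) is a modest step. The next compound is compound 4 `COc1cc(-c2cccc3nc(-c4cccc(Br)c4)oc23)cc(OC)c1OC`, with the change (3-bromophenyl in place of 3-fluoro-4-methoxyphenyl on an aromatic carbon). This puts 3-bromophenyl in place of 3-fluoro-4-methoxyphenyl on an aromatic carbon, next to the ring nitrogen and next to the ring oxygen.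

Two measured steps show how far this group can move the number. Methoxy in place of hydrogen gave an at least 7.1-fold higher number from compound 1 to compound 2 (0.85 log units; beyond the scatter), and fluoro in place of hydrogen gave an at least 14-fold lower number from compound 2 to compound 3 (1.16 log units; beyond the scatter). Compound 4 has neither group, so it compares best with compound 1 at 3500 nM. Among the compounds with values here, no measured step covers bromo. A small move towards a higher number is therefore expected, not clearly beyond the scatter: a 1.5-fold higher number from compound 3 to compound 4 (0.17 log units; within the scatter). Compound 4 is estimated at 2500 nM, with an expected range of 700 nM to 9000 nM.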

Compound 4, half-maximal inhibitory concentration: 6800 nM
Compound 4: the middle estimate sits 2.7-fold (0.43 log units) below what was measured; low and high end bracket the measured number.
By their numbers in this assay, from the lowest: compound 3; then compounds 1 and 4 (each within the scatter of the next). At a limit, above all of these: compound 2.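

Bromo on the phenyl group does not separate compound 4 from the unsubstituted parent, a 1.9-fold higher number from compound 1 to compound 4 (0.29 log units; within the scatter), yet it does leave compound 4 apart from the fluoro and methoxy pair, a 4.0-fold higher number from compound 3 to compound 4 (0.60 log units; beyond the scatter), so 3-fluoro-4-methoxyphenyl remains the only group shown that reads lower than phenyl beyond the scatter. Against 4-methoxyphenyl, the only reading is an at least 3.6-fold lower number from compound 2 to compound 4 (0.56 log units; beyond the scatter). Compound 2 gives a limit, not a number: the limit of > 25000 nM in this assay, at which 1 of the 4 values shown sits.

The compounds shown leave open whether the low number of compound 3 would hold with fluoro alone, as in 3-fluorophenyl, without the methoxy. Also open, as far as these compounds go, is how an amine or a carboxylic acid on this phenyl ring would compare with bromo.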